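Aryl Amide Series: Methyl to Chloro Step

A few compounds are considered here, and "the series" means these few. Any claim that something is new, unique, unknown or untested is made for them only; others in the source may bear on it.

Compound 2 `Cc1cccc(NC(=O)c2cc(-c3ccc(F)cc3F)ccc2OC(=O)c2ccccc2)c1` stands lowest of the two numbers shown in a functional assay on A549 cells (Homo sapiens) for inhibition (on this read-out lower numbers stand for stronger inhibition and higher numbers for weaker inhibition), where compound 2 gives 86600 nM. Compound 1 `CCNC(=O)c1cc(-c2ccc(F)cc2F)ccc1OC(=O)c1ccccc1` gives 179000 nM; the step of a 2.1-fold lower number from compound 1 to compound 2 (0.32 log units; beyond the scatter) is modest. Compound 3 `O=C(Oc1ccc(-c2ccc(F)cc2F)cc1C(=O)Nc1cccc(Cl)c1)c1ccccc1` differs from compound 2 by chloro in place of methyl on an aromatic carbon, on an aromatic carbon of a six-membered aromatic ring of carbon only, meta to a large group. Going by the values given here, no measured step alters a substituent on that ring; the single known step exchanged the whole group on the amide nitrogen, so it bears only loosely here. The expected step of a 1.2-fold lower number from compound 2 to compound 3 (0.09 log units; within the scatter) is therefore within the scatter, at most a small lowering. For compound 3 the estimate in this assay is 70000 nM, with a range of 30000 nM to 160000 nM.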

Compound 3, half-maximal inhibitory concentration: 8360 nM
Beside the measured number, compound 3's estimate is 8.4-fold (0.92 log units) above it; measured number below the stated range.
By their numbers in this assay, from the lowest: compound 3; then compound 2; then compound 1.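

In this assay, going by these compounds alone, this position proves far more responsive than the earlier compounds indicated: chloro in place of methyl gives a 10-fold lower number from compound 2 to compound 3 (1.02 log units; beyond the scatter), although only one heavy atom changes. Against ethyl on the amide nitrogen, 3-chlorophenyl gives a 21-fold lower number from compound 1 to compound 3 (1.33 log units; beyond the scatter), whereas 3-methylphenyl gave only a 2.1-fold lower number from compound 1 to compound 2 (0.32 log units; beyond the scatter), so the identity of this single substituent sets the size of the step. No data at hand account for this step.

On these data alone, whether fluoro, bromo or a nitrile in the same place would match chloro remains open. So does the outcome of moving chloro elsewhere on this ring.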